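A few compounds are considered here, and "the series" means these few. Any claim that something is new, unique, unknown or untested is made for them only; others in the source may bear on it.

Measured in a functional assay on HepG2 cells (Homo sapiens) for inhibition, read by MTT assay, with a stated time of 72 h; on this read-out higher numbers stand for weaker inhibition and lower numbers for stronger inhibition:
compound 1 `CCc1ccc(-n2cc(COc3cccc(NC(=O)Nc4ccc(Cl)c(C(F)(F)F)c4)c3)nn2)cc1`, 1950 nM
compound 2 `O=C(Nc1cccc(OCc2cn(-c3cccc(F)c3)nn2)c1)Nc1ccc(Cl)c(C(F)(F)F)c1`, 2120 nM
compound 3 `O=C(Nc1cccc(OCc2cn(-c3ccc(F)cc3)nn2)c1)Nc1ccc(Cl)c(C(F)(F)F)c1`, 1350 nM

Compound 3 gives the lowest of these three numbers, yet each gap to the others lies within the scatter: a 1.4-fold lower number from compound 1 to compound 3 (0.16 log units; within the scatter) and a 1.6-fold lower number from compound 2 to compound 3 (0.20 log units; within the scatter). Compound 4 `O=C(Nc1cccc(OCc2cn(-c3cccc(I)c3)nn2)c1)Nc1ccc(Cl)c(C(F)(F)F)c1` differs from compound 3 in one place: 3-iodophenyl in place of 4-fluorophenyl on an aromatic nitrogen. Among the compounds with values here, two measured steps bear on this change. The exchange of 3-fluorophenyl for 4-fluorophenyl, a 1.6-fold lower number from compound 2 to compound 3 (0.20 log units; within the scatter), changed little, and the exchange of 4-ethylphenyl for 3-fluorophenyl, a 1.1-fold higher number from compound 1 to compound 2 (0.04 log units; within the scatter), changed little as well. Nothing here points to a step beyond the scatter for compound 4 in this assay, so the expected step is a 1.1-fold higher number from compound 3 to compound 4 (0.05 log units; within the scatter). Compound 4 is therefore estimated at 1500 nM, with a range from 700 nM to 3500 nM.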

Compound 4, half-maximal inhibitory concentration: 4780 nM
For compound 4 the middle estimate is 3.2-fold (0.50 log units) below the measured one; the measured number lies above the stated range.
By their numbers in this assay, from the lowest: compounds 3, 1 and 2 (each within the scatter of the next); then compound 4.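

Within the data shown here, the 3-iodophenyl group is the first change on this aromatic nitrogen to move the number beyond the scatter in this assay (a 3.5-fold higher number from compound 3 to compound 4 (0.55 log units; beyond the scatter)), and the same holds against the ethyl compound (a 2.5-fold higher number from compound 1 to compound 4 (0.39 log units; beyond the scatter)). The cleanest comparison swaps only fluoro for iodo on an aromatic carbon (a 2.3-fold higher number from compound 2 to compound 4 (0.35 log units; beyond the scatter)), so this ring does respond to the atom it carries. Nothing measured here explains the rise.

On these data alone, whether the rise belongs to iodo alone stays open: 3-chlorophenyl, 3-bromophenyl and 4-iodophenyl groups would test that. How an amine or a carboxylic acid on this ring would fare is also unknown.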